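Piperidine nitrogen substituent: carbamate to oxadiazolylmethyl

A few compounds are considered here, and "the series" means these few. Any claim that something is new, unique, unknown or untested is made for them only; others in the source may bear on it.

Measured so far in a functional assay on isolated protein for agonist activity at Glucose-dependent insulinotropic receptor (Homo sapiens), read by HTRF and cAMP accumulation; a lower number here means that less compound is needed, a higher number that more compound is needed for the effect:
compound 1, `CC(C)(C)OC(=O)N1CCC(O[C@H]2CC[C@H](Oc3ccc(S(C)(=O)=O)c(F)c3)CC2)CC1`, gives 52 nM
compound 2, `C[C@@H](CF)OC(=O)N1CCC(O[C@H]2CC[C@H](Oc3cnc(S(C)(=O)=O)cn3)CC2)CC1`, gives 31.1 nM
compound 3, `CS(=O)(=O)c1cnc(O[C@H]2CC[C@H](OC3CCN(C(=O)Oc4ccccc4)CC3)CC2)cn1`, gives 9.6 nM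

Compound 3 stands lowest of the three in this assay; its nearest neighbour is compound 2, and compound 1 lies furthest from it. For the measured compounds named here, the one single-point step in the set, a 3.2-fold lower number from compound 2 to compound 3 (0.51 log units; beyond the scatter), shows that the group carried on the carbamate oxygen shifts the number by a modest but real amount. Compounds 1 and 2 differ in more than one place, so their two values are only noted side by side.

Compound 4, `CC(F)Cc1nc(CN2CCC(O[C@H]3CC[C@H](Oc4cnc(S(C)(=O)=O)cn4)CC3)CC2)no1`, is the next compound. The change is (5-(2-fluoropropyl)-1,2,4-oxadiazol-3-yl)methyl in place of phenoxycarbonyl on an amine nitrogen in a ring. Going by the values given here, no measured step touches this position in this way: the carbamate itself is removed and an oxadiazolylmethyl group is placed directly on the ring nitrogen, a larger change than the one in a 3.2-fold lower number from compound 2 to compound 3 (0.51 log units; beyond the scatter). The direction is therefore open; a modest shift in either direction beyond the scatter is expected, with a wide range, a 3.1-fold higher number from compound 3 to compound 4 (0.49 log units; beyond the scatter). Compound 4 is estimated at 30 nM in this assay, between 8 nM and 120 nM.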

Compound 4, half-maximal effective concentration: 30.3 nM
The estimate for compound 4 lay 1.0-fold (0.00 log units) below the measured number; the measured number falls inside the stated range.
By their numbers in this assay, from the lowest: compound 3; then compounds 4, 2 and 1 (each within the scatter of the next).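

Replacing phenoxycarbonyl with (5-(2-fluoropropyl)-1,2,4-oxadiazol-3-yl)methyl on the amine nitrogen in the ring gives a 3.2-fold higher number from compound 3 to compound 4 (0.50 log units; beyond the scatter) in this assay, so activity at this position does not depend on a carbamate, although the phenyl carbamate keeps a modest edge. Against the 1-(fluoromethyl)ethyl carbamate, the same group gives a 1.0-fold lower number from compound 2 to compound 4 (0.01 log units; within the scatter), so the two groups cannot be told apart here despite the loss of the carbonyl. No measurement available here accounts for either step.

The compounds shown leave open whether the 2-fluoropropyl group on the oxadiazole can be exchanged for a phenyl group or a longer chain without a shift in the number. From the compounds shown here alone, it is also open whether an amide in place of the oxadiazole would give a similar value.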